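This account rests on a few compounds, and the source may have more. Where it says the series, first, only, none or still open, it means among the compounds named here.

Compound 1, `CC(C)(C)[C@@H](N)C(=O)NCc1ccc(COc2cccc(F)c2)cc1`, gives 30 mg/kg in a functional assay on the whole organism (strain albino Sprague-Dawley) with Rattus norvegicus as the target, in the maximal electroshock model; a lower number here means that less compound is needed, a higher number that more compound is needed for the effect.
Compound 2, `CC(C)(C)[C@@H](N)C(=O)NCc1ccc(C(F)(F)F)cc1`, gives in this assay only a limit, < 30 mg/kg.
Compound 3, `CC(C)[C@@H](N)C(=O)NCc1ccc(C(F)(F)F)cc1`, gives 13 mg/kg in this assay.

Among the two numbers, compound 3 stands lowest; its nearest neighbour is compound 1, whose number is higher by a margin beyond the usual scatter. The step that the limit leaves unreadable from compound 2 to compound 3 cannot be read because of the limit of < 30 mg/kg in this assay, at which 1 of the 3 values shown sits.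

The unmeasured compound 4 is `CC(C)[C@@H](N)C(=O)NCc1ccc(-c2ccccc2)cc1`. It differs from compound 3 in one place: phenyl in place of trifluoromethyl on an aromatic carbon. Within the data shown here, no measured step exchanges these two groups, and compound 1 differs from compound 3 in more than one place, so its value only shows a higher number than that of compound 3. With nothing to point in either direction, the step from compound 3 to compound 4 is expected to stay within the scatter, a 1.5-fold higher number from compound 3 to compound 4 (0.19 log units; within the scatter). Compound 4 is therefore estimated at 20 mg/kg in this assay, expected to lie between 7 mg/kg and 60 mg/kg.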

Compound 4, dose for half-maximal effect: 30 mg/kg
For compound 4 the middle estimate is 1.5-fold (0.18 log units) below the measured one; the range from low to high includes it.
By their numbers in this assay, from the lowest: compound 3; then compounds 1 and 4 (each within the scatter of the next).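

In this assay, among these compounds, the exchange of trifluoromethyl for phenyl, on an aromatic carbon para to a group of 9 heavy atoms, gives a 2.3-fold higher number from compound 3 to compound 4 (0.36 log units; beyond the scatter) and is the only measured exchange at this place. It shows that this carbon can carry a six-membered aromatic ring of carbon only, with 6 heavy atoms entering where 4 leave, and that the effect in the whole animal is kept, although somewhat more compound is needed. Nothing measured here accounts for the size of this step.

Going by these compounds, with a single exchange at this place, it stays open how a nitrile, a chlorine atom or a methoxy group would compare with trifluoromethyl and phenyl. Also open, on these data alone, is whether phenyl would give a step of similar size on the core of compound 2, whose only reading is a limit.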